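Urea series: anilinopyrimidine halogenated aryl swap, single-point cell inhibition

This account rests on a few compounds, and the source may have more. Where it says the series, first, only, none or still open, it means among the compounds named here.

Measured compounds:
compound 1 `Cc1ccc(Nc2cc(NC(=O)Nc3c(Cl)cccc3Cl)ncn2)cc1F`, 33.5%
compound 2 `CCc1ccc(Nc2cc(NC(=O)Nc3cc(OC)cc(OC)c3)ncn2)cc1`, 23.5%
compound 3 `Cc1ccc(Nc2cc(NC(=O)Nc3c(Cl)cccc3Cl)ncn2)cc1C`, 47.5%

In a functional assay on NCI-H520 cells (Homo sapiens) for inhibition, read by MTT assay, with a stated time of 48 h, tested at 10 uM (on this read-out higher numbers stand for more inhibition at the one concentration tested (going by the name of the read-out) and lower numbers for less inhibition), compound 2 gives 23.5%, the lowest of the three numbers. Its gap to compound 1, at 33.5%, lies within the scatter of repeated runs, so no order between compound 2 and compound 1 can be read; its gap to compound 3, at 47.5%, lies beyond the scatter.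

Compound 4 `COc1cc(NC(=O)Nc2cc(Nc3ccc(F)c(Cl)c3)ncn2)cc(OC)c1` differs from compound 2 by 3-chloro-4-fluorophenyl in place of 4-ethylphenyl on a nitrogen on an aromatic ring.

Within the data shown here, the one measured step, a number 14 percentage points higher from compound 1 to compound 3 (beyond the scatter), concerns the other aromatic ring of the shared core (methyl in place of fluoro on an aromatic carbon) and not the arylamino ring changed here; it bears on the present step only indirectly. Among the measured compounds shown here, no measured pair separates an alkyl-bearing arylamino from a halogen-bearing one while the urea aryl is held fixed, so the direction of the step from compound 2 to compound 4 is not anchored. Given the modest size of the only step seen, the expectation for a number 4.5 percentage points higher from compound 2 to compound 4 (within the scatter) is a change not clearly beyond the scatter, with a wide range. For compound 4 in this assay the estimate is 28%, from 10% to 50%.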

Compound 4, a percentage reported as inhibition, at one concentration (the size of the read-out at that concentration, not a potency): 25.5%
For compound 4 the middle estimate is 2.5 percentage points above the measured one; measured number inside the range.
By their numbers in this assay, from the lowest: compounds 2, 4 and 1 (each within the scatter of the next); then compound 3.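

In this assay, among these compounds, the one pair that changes the group on this nitrogen while the urea aryl stays fixed gives a number 2 percentage points higher from compound 2 to compound 4 (within the scatter). With this urea aryl, 3-chloro-4-fluorophenyl in place of 4-ethylphenyl on a nitrogen on an aromatic ring therefore has no readable effect, and an alkyl-bearing group and a halogen-bearing group cannot be told apart here on this single pair. Nothing available speaks to the reason for this result.

Among the compounds shown here, whether the same swap would also stay within the scatter with the chlorine-bearing urea aryl of compound 1 and compound 3 remains open, as the step of a number 14 percentage points higher from compound 1 to compound 3 (beyond the scatter) belongs to that other urea aryl and is the only step there. Also open, on these data alone, is how this assay would respond to a group of another kind in place of 4-ethylphenyl, such as a morpholine ring, a carboxylic acid or a longer alkyl chain, with the urea aryl of compound 2 held fixed.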